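The source may hold more compounds than are shown below. What is called first, only, known or untested is meant among the compounds shown, and "the series" means these compounds.

Of the compounds shown here, three built on a shared core have so far been measured in an assay on mitochondria for inhibition of Amine oxidase [flavin-containing] A (Rattus norvegicus); on this read-out lower numbers stand for stronger inhibition and higher numbers for weaker inhibition. Compound 1, `NC(=O)CNCc1ccc(OCc2ccc([N+](=O)[O-])cc2)cc1`, gives 21200 nM in this assay. Compound 2, `C[C@H](NCc1ccc(OCc2ccccc2)cc1)C(N)=O`, gives 101000 nM. Compound 3, `NC(=O)[C@@H](CO)NCc1ccc(OCc2cccc(Cl)c2)cc1`, gives 100000 nM. Compound 2 thus stands at the highest of the three numbers, although its number and that of compound 3 lie within the scatter of one another; only compound 1 sits apart from it, beyond the scatter.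

Compound 4, `NC(=O)[C@H](CO)NCc1ccc(OCc2ccccc2)cc1`, has not yet been measured in this assay. It differs from compound 2 in a single place: hydroxy in place of hydrogen on a saturated chain carbon, two bonds along the chain from an amine nitrogen and a carbonyl carbon. Within the data shown here, no pair of measured compounds differs in exactly that place, so there is no measured step to lean on. What the data do show is that compound 3, which carries the hydroxymethyl, and compound 2, which carries the methyl, give numbers within the scatter of each other. On that basis the change is expected to bring no shift beyond the scatter, in either direction, a 1.0-fold lower number from compound 2 to compound 4 (0.00 log units; within the scatter). Compound 4 is therefore estimated at 100000 nM in this assay, within a range of 40000 nM to 250000 nM.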

Compound 4, half-maximal inhibitory concentration: 90000 nM
The estimate for compound 4 lay 1.1-fold (0.05 log units) above the measured number, and the stated range covers the measured number.
By their numbers in this assay, from the lowest: compound 1; then compounds 4, 3 and 2 (each within the scatter of the next).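

With compound 4, the position has its first direct reading in this assay: methyl to hydroxymethyl, on a saturated chain carbon two bonds along the chain from an amine nitrogen and a carbonyl carbon, gives a 1.1-fold lower number from compound 2 to compound 4 (0.05 log units; within the scatter). The earlier compounds shown here allowed only an indirect view, since the compounds carrying these two groups also differed elsewhere, whereas this step isolates the single hydroxy and shows that it does not separate the two compounds on this read-out. The data offer no measurement that could account for the size of this step.

The compounds shown leave open whether this position stays as flat for other groups, such as an aminomethyl, a carboxylic acid or a longer chain like 2-hydroxyethyl, or whether methyl and hydroxymethyl merely happen to match. Among these compounds, they also leave open whether the same step would hold on a core bearing a chloro or nitro group on the outer ring, since the single one-place step available here rests on the unsubstituted benzyloxy compounds alone.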